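Lengthening the Side Chain on a Charged Oxime Core

The compounds below may be only part of what the source reports. "The series", "measured", "known", "first", "only" and "open" are said of these compounds alone.

Compound 1, `C[n+]1ccn(CCOCCS(C)(=O)=O)c1/C=N/O`, gives < -3 in a physicochemical assay for lipophilicity; on this read-out higher numbers stand for higher lipophilicity and lower numbers for lower lipophilicity; this is a limit of the assay, not a number.
Compound 2, `CC[n+]1ccn(CCN(C)C)c1/C=N/O`, gives -2.71 in this assay.

Of the two measurements, only compound 2 yields an actual number; for compound 1 the assay reports only (the limit of < -3 in this assay, at which 1 of the 2 values shown sits). Compound 3, `CCC[n+]1ccn(CCN(C)C)c1/C=N/O`, differs from compound 2 by methyl in place of hydrogen on a saturated chain carbon, two bonds along the chain from an aromatic nitrogen. Among the compounds with values here, no measured step of this kind exists here to lean on, so a small upward step in this assay is expected, possibly within the scatter. Compound 3 is therefore estimated at -2.3, between -2.8 and -1.8. The expected step of a number 0.41 log units higher from compound 2 to compound 3 (beyond the scatter) is modest.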

Compound 3, distribution coefficient: -2.73
Compound 3: the middle estimate sits 0.43 log units above what was measured; measured number inside the range.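

Swapping ethyl for propyl, which places methyl in place of hydrogen on a saturated chain carbon, two bonds along the chain from an aromatic nitrogen, gives the first measured step at this position in this assay, a number 0.02 log units lower from compound 2 to compound 3 (within the scatter) and so the two compounds cannot be told apart on this read-out. Nothing measured here gives a reason for this result.

Going by these compounds, whether a longer chain such as hexyl, or a phenyl ring, at this position would give a step beyond the scatter remains open. So does the effect of a carboxylic acid there.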